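This account rests on a few compounds, and the source may have more. Where it says the series, first, only, none or still open, it means among the compounds named here.

Values in a functional assay on HT-29 cells (Homo sapiens) for cytotoxicity, read by MTT assay, with a stated time of 72 h; a higher number here means a weaker inhibitor, a lower number a stronger inhibitor:
compound 1 `COc1ccc(/C=C2\S/C(=N\c3csc(-c4ccc(Cl)cc4)c3)NC2=O)cc1` gives 3800 nM;
compound 2 `Cc1ccc(/C=C2\S/C(=N\c3csc(-c4ccc(Cl)cc4)c3)NC2=O)cc1` gives 6400 nM;
compound 3 `COc1cccc(N2C(=O)CS/C2=N\c2csc(-c3ccc(C)cc3)c2)c1` gives > 50000 nM, which is a limit of the assay and not a number.

Compounds 1 and 2 share one core and differ in a single place: methoxy in place of methyl on an aromatic carbon. That change gave a 1.7-fold lower number from compound 2 to compound 1 (0.23 log units; within the scatter). Compound 3 carries a different core from compound 2, and the difference between the two cores is not broken down here. For compound 3 only a limit is known, and it sits at the limit of > 50000 nM in this assay, at which 1 of the 3 values shown sits.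

Compound 4 `COc1ccc(-c2cc(/N=C3\SCC(=O)N3c3cccc(OC)c3)cs2)cc1` is still to be measured in this assay. It differs from compound 3 in one place: methoxy in place of methyl on an aromatic carbon. This is the same change as from compound 2 to compound 1, made at a place described in the same words, so it is treated as the same change on the core of compound 3. Since that earlier change gave a 1.7-fold lower number from compound 2 to compound 1 (0.23 log units; within the scatter), the step is expected to stay small. The expected step is a step that the limit leaves unreadable from compound 3 to compound 4. Compound 4 is therefore estimated at 60000 nM, within a range from 20000 nM to 200000 nM, with a fair chance that only a limit is reported again.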

Compound 4, half-maximal inhibitory concentration: 11700 nM
For compound 4 the middle estimate is 5.1-fold (0.71 log units) above the measured one, and the stated range ends above it.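

In this assay, methoxy in place of methyl on the core of compound 3 gave an at least 4.2-fold lower number from compound 3 to compound 4 (0.63 log units; beyond the scatter), while the same change on the core of compound 1 gave a 1.7-fold lower number from compound 2 to compound 1 (0.23 log units; within the scatter). For compound 3, > 50000 nM is a limit of the assay and not a number, so the step on this core has a known minimum but no known size. The change therefore carries over to the second core with a lower number again, but the two results do not show that its size depends on the core, nor that it stays the same from one core to the other: the same change on two cores in this assay, a 1.7-fold lower number (0.23 log units; within the scatter) from compound 2 to compound 1 and an at least 4.2-fold lower number (0.63 log units; beyond the scatter) from compound 3 to compound 4; the limit leaves it open whether they differ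

The compounds shown leave open how an amine, a hydroxyl or a carboxylic acid at this place would read in this assay. For the compounds shown here, they also leave open whether methoxy in place of methyl would give a lower number on any third core, since only two pairs carry this change.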